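The compounds below may be only part of what the source reports. "The series", "measured", "known", "first", "only" and "open" are said of these compounds alone.

Values measured so far in a functional assay on MT4 cells (Homo sapiens) for cytotoxicity; a lower number here means a stronger inhibitor, a higher number a weaker inhibitor:
- compound 1 `CCN(CC)CCNc1nc2c(c(=N)n1-c1ccccc1)c(=S)n(-c1ccccc1)c(=S)n2-c1ccccc1`: 2500 nM
- compound 2 `CN(C)CCCNc1nc2c(c(=N)n1-c1ccccc1)c(=S)n(-c1ccccc1)c(=S)n2-c1ccccc1`: 1700 nM
- compound 3 `N=c1c2c(=S)n(-c3ccccc3)c(=S)n(-c3ccccc3)c2nc(NCc2ccccn2)n1-c1ccccc1`: 7000 nM

Of these three, compound 3 has the highest number, 7000 nM, making it the weakest inhibitor in this assay. The next compound, compound 4 `N=c1c2c(=S)n(-c3ccccc3)c(=S)n(-c3ccccc3)c2nc(NNc2ccccc2)n1-c1ccccc1`, has anilino in place of (pyridin-2-yl)methyl on a nitrogen on an aromatic ring. The two compounds contain the same atoms, joined differently.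

The closest evidence comes from changes to the same side chain. These gave a 2.8-fold higher number from compound 1 to compound 3 (0.45 log units; beyond the scatter) and a 4.1-fold higher number from compound 2 to compound 3 (0.61 log units; beyond the scatter), both modest, while a 1.5-fold lower number from compound 1 to compound 2 (0.17 log units; within the scatter) stayed within the scatter. Within the data shown here, no measured step introduces anilino or removes the pyridine ring, so these steps offer only a rough guide to size. Neither compound 3 nor compound 4 carries the diethylamino or dimethylamino group, so no step beyond the scatter is expected. The expected change is a 1.3-fold lower number from compound 3 to compound 4 (0.10 log units; within the scatter). For compound 4 the estimated value is 5500 nM, with an expected range from 2000 nM to 15000 nM.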

Compound 4, half-maximal inhibitory concentration: > 100000 nM
Compound 4: no number, only a limit; the forecaster's own chance of this, stated with the estimate: 10%; at least 18-fold (1.25 log units) between middle value and limit.
By their numbers in this assay, from the lowest: compounds 2 and 1 (each within the scatter of the next); then compound 3. At a limit, above all of these: compound 4.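

In this assay, compound 4 gives only a limit, not a number: the limit of > 100000 nM in this assay, at which 1 of the 4 values shown sits.

Anilino in place of (pyridin-2-yl)methyl on this nitrogen, with the same atoms joined differently, gives an at least 14-fold higher number from compound 3 to compound 4 (1.15 log units; beyond the scatter), a larger step than any among the earlier compounds, all of which have a saturated chain carbon on this nitrogen. Among these compounds, the gap is also large against the two amine chains, with an at least 58-fold higher number from compound 2 to compound 4 (1.76 log units; beyond the scatter) and an at least 40-fold higher number from compound 1 to compound 4 (1.60 log units; beyond the scatter), so this position can move the number much further than the earlier steps showed.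

This change alters the ring and its link to the nitrogen at once, and the compounds shown do not separate the two. A benzyl group, which pairs the carbon-only ring with a chain carbon, would help pull these two parts apart.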